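The compounds below may be only part of what the source reports. "The series", "measured", "known", "first", "only" and "open" are said of these compounds alone.

Measured so far in an ADME assay on MT4 cells (Homo sapiens) for cytotoxicity; on this read-out higher numbers stand for lower toxicity in this test and lower numbers for higher toxicity in this test:
Compound 1 `COC(=O)N[C@H](C(=O)NN(CCC[C@@](O)(Cc1ccccc1)C(=O)N[C@H]1c2ccccc2C[C@H]1O)Cc1ccc(Cl)cc1)C(C)(C)C`: > 10000 nM
Compound 2 `COC(=O)N[C@H](C(=O)NN(CCC[C@@](O)(Cc1ccccc1)C(=O)N[C@H]1c2ccccc2C[C@H]1O)Cc1ccc(-c2noc(C)n2)cc1)C(C)(C)C`: > 10000 nM

Neither entry is a number, as both compounds sit at the same point: the limit of > 10000 nM in this assay, at which 2 of the 2 values shown sit.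

Compound 2 gives > 10000 nM, which is a limit. Going by the values given here, the only other value available for comparison is also a limit, so compound 2 cannot be ranked on these data.

The next compound is compound 3 `COC(=O)N[C@H](C(=O)NN(CCC[C@@](O)(Cc1ccccc1)C(=O)N[C@H]1c2ccccc2C[C@H]1O)Cc1ccc(I)cc1)C(C)(C)C`, and the change from compound 2 is iodo in place of 5-methyl-1,2,4-oxadiazol-3-yl on an aromatic carbon. It lies on an aromatic carbon of a six-membered aromatic ring of carbon only, para to a large group.

Among the compounds with values here, one measured step bears on this change, a step that the two limits leave unreadable from compound 1 to compound 2, and it gives no size to carry over. The expectation rests instead on compound 1, which has chloro on that aromatic carbon and gives > 10000 nM, a limit. No step beyond the scatter is therefore expected in this assay, and no direction can be assigned.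

The estimated change is a number no higher from compound 2 to compound 3 (the limit leaves the size open).

For compound 3 the expected value is 10000 nM, with an estimated range from 5000 nM to 20000 nM.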

Compound 3, half-maximal cytotoxic concentration: > 10000 nM
Compound 3 ended at the assay's limit; the forecaster's own chance of this, stated with the estimate: 85%; the middle value lies on the limit itself.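

In this assay compound 3 gives > 10000 nM, which is a limit. No step to compound 3 from compound 1 or compound 2 can be read, as all three compounds share one point: the limit of > 10000 nM in this assay, at which 3 of the 3 values shown sit.

The compounds shown leave open how far any of their half-maximal cytotoxic concentrations lies from that limit, and whether exchanging the group on this aromatic carbon changes it at all.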